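Notes on compound 2 and its sec-butyl ester, compound 4

The compounds below may be only part of what the source reports. "The series", "measured", "known", "first", "only" and "open" are said of these compounds alone.

Three compounds have numbers in a functional assay on COLO 205 cells (Homo sapiens) for activation, read by flow cytometry, with a stated time of 24 h, tested at 5 uM; a higher number here means a stronger effect of the compound at the concentration tested, a lower number a weaker effect. Compound 1 `C=C1C(=O)O[C@@H]2CC(C)=C([C@@H](C)CCCOC(C)=O)[C@H](OC(C)=O)[C@H]12` gives 6.94% in this assay. Compound 2 `C=C1C(=O)O[C@@H]2CC(C)=C([C@@H](C)CCCO)[C@H](O)[C@H]12` gives 11.9% in this assay. Compound 3 `CC(=O)OCCC[C@H](C)C1=C[C@@H]2[C@H](C)C(=O)O[C@@H]2C[C@@]1(C)O` gives 4.08% in this assay. Compound 2 thus holds the top number of the three, but compound 1 and compound 3 both sit within the usual scatter of it, so no ranking among the three is supported and all three readings are small.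

Compound 4 `C=C1C(=O)O[C@@H]2CC(C)=C([C@@H](C)CCCO)[C@H](OC(=O)C(C)CC)[C@H]12` is to be measured in this assay. It differs from compound 2 in one place: (sec-butyl)carbonyl in place of hydrogen on an oxygen on a saturated carbon. Going by the values given here, no pair of measured compounds differs in exactly one place, so no single step is available as a guide. What the series does show is that compound 1 and compound 2, the two with the shared core that carry either both or neither oxygen acylated, give numbers within the scatter of each other. The expected step is therefore a number 2.9 percentage points lower from compound 2 to compound 4 (within the scatter), small and of no direction beyond the scatter. Compound 4 is expected to give about 9% in this assay, within an estimated range of 2% to 20%.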

Compound 4, a percentage reported as activity, at one concentration (the size of the read-out at that concentration, not a potency): 5.33%
Compound 4: middle estimate off by 3.7 percentage points, on the high side; measured number inside the range.
By their numbers in this assay, from the lowest: compounds 3, 4, 1 and 2 (each within the scatter of the next).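

In this assay, going by these compounds alone, the change from hydroxy to ((sec-butyl)carbonyl)oxy gives a number 6.6 percentage points lower from compound 2 to compound 4 (within the scatter), the only single-place step available. At this oxygen on a saturated carbon, then, the hydrogen can give way to (sec-butyl)carbonyl without a shift beyond the scatter, so this one step gives no sign that the free hydroxy matters for the reading at the tested concentration. Nothing measured here bears on the reason for this outcome.

Going by these compounds, whether any group on this oxygen can move the reading beyond the scatter remains open, for instance a simple acetyl, a longer acyl chain such as octanoyl, or an acyl chain ending in an amine or a carboxylic acid. On these data alone, the effect of acylating the other hydroxy alone, at the end of the chain, is also open.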